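Adding a Nitro Group to the Strongest Compound So Far

The compounds below may be only part of what the source reports. "The series", "measured", "known", "first", "only" and "open" are said of these compounds alone.

Measured compounds:
compound 1 `COc1ccc(/C=C/C=C/C(=O)c2ccccc2O)cc1OC`: 14600 nM
compound 2 `O=C(/C=C/C=C/c1ccccc1)c1cc(Cl)ccc1O`: 54.8 nM
compound 3 `COc1cc(/C=C/C=C/C(=O)c2ccccc2O)ccc1O`: 502 nM

Of the compounds shown here, three have been tested in an in vitro assay on cells for inhibition of Amine oxidase [flavin-containing] B (Homo sapiens), read by Amplex Red, with a stated time of 15 min; a lower number here means a stronger inhibitor, a higher number a weaker inhibitor. Compound 2 shows the lowest number of the three and is therefore the strongest inhibitor measured; compound 3 stands nearest to it and compound 1 furthest away. Within the data shown here, only one pair of measured compounds differs in a single place, and that step was large: a 29-fold lower number from compound 1 to compound 3 (1.46 log units; beyond the scatter). It shows that a small change on the ring at the far end of the chain can move the number a long way.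

Compound 4 `O=C(/C=C/C=C/c1ccc([N+](=O)[O-])cc1)c1cc(Cl)ccc1O` is built from compound 2 by one change: nitro in place of hydrogen on an aromatic carbon. Among the measured compounds shown here, no measured step adds a nitro group or touches this position, so nothing in the data speaks directly to the size or direction of this change. Given how much the far ring mattered in the one step seen, a clear shift is possible, but its direction cannot be read from the data, so a moderate step is expected, a 2.2-fold higher number from compound 2 to compound 4 (0.34 log units; beyond the scatter). Compound 4 is therefore estimated at 120 nM, with a range from 25 nM to 600 nM.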

Compound 4, half-maximal inhibitory concentration: 1080 nM
The estimate for compound 4 lay 9.0-fold (0.95 log units) below the measured number; the measured number lies above the stated range.
By their numbers in this assay, from the lowest: compound 2; then compound 3; then compound 4; then compound 1.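

In this assay, placing nitro on the far ring, para to a large group, gives a 20-fold higher number from compound 2 to compound 4 (1.29 log units; beyond the scatter), so this carbon does not accept every added group without a large loss of inhibition. The earlier step, a 29-fold lower number from compound 1 to compound 3 (1.46 log units; beyond the scatter), showed that the far ring matters, but only as a move towards a lower number between two rings that both carry oxygen groups; the new step shows that a change on this ring can also push the number strongly upward, and that hydrogen on this carbon is much better than nitro in the core of compound 2. Nothing measured here explains why this addition has so large an effect.

On these data alone, it remains open whether the loss belongs to nitro itself or would follow any group placed on this carbon, a question that an amine, a carboxylic acid or a single fluorine atom in the same place could help to settle. As far as these compounds go, it is also open whether nitro on another carbon of this ring, or on a core without the chlorine, would give a step of similar size.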